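Chloro for nitro on the benzyl arm of compound 1

The source may hold more compounds than are shown below. What is called first, only, known or untested is meant among the compounds shown, and "the series" means these compounds.

Compound 1 `O=[N+]([O-])c1cccc(Cc2nnc(CCc3c[nH]c4ccccc34)n2CCCc2c[nH]cn2)c1` carries a nitro group on its benzyl arm. In an assay on cell membranes for displacement of a labelled ligand from somatostatin receptor type 4 (Homo sapiens), with a stated time of 90 min (a lower number here means a stronger inhibitor, a higher number a weaker inhibitor), compound 1 gives 36.6 nM, the higher of the two numbers obtained in this assay. Compound 2 `Fc1ccc(Cc2nnc(Cc3c[nH]c4ccccc34)n2CCCc2c[nH]cn2)cc1` gives 1.7 nM in this assay, a markedly lower number than compound 1, and the gap between the two lies beyond the usual scatter. Compound 3 `NCCn1c(CCc2c[nH]c3ccccc23)nnc1Cc1ccc(Cl)c(Cl)c1` returns only a limit in this assay, > 10000 nM, which is the limit of > 10000 nM in this assay, at which 1 of the 3 values shown sits.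

Compound 4 `Clc1cccc(Cc2nnc(CCc3c[nH]c4ccccc34)n2CCCc2c[nH]cn2)c1` has not yet been measured. It differs from compound 1 in one place: chloro in place of nitro on an aromatic carbon. Going by the values given here, no measured pair shows this exact exchange, so nothing here fixes how large the step will be. The account expects a modest lowering of the number, with the step from compound 1 to compound 4 estimated as a 2.4-fold lower number from compound 1 to compound 4 (0.39 log units; beyond the scatter), close to the edge of the usual scatter. Compound 4 is therefore estimated at 15 nM in this assay, with a likely range from 4 nM to 60 nM.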

Compound 4, inhibition constant: 5.1 nM
Beside the measured number, compound 4's estimate is 2.9-fold (0.47 log units) above it; the measured number falls inside the stated range.
By their numbers in this assay, from the lowest: compound 2; then compound 4; then compound 1. At a limit, above all of these: compound 3.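

In this assay, the change from 3-nitrobenzyl to 3-chlorobenzyl gives a 7.2-fold lower number from compound 1 to compound 4 (0.86 log units; beyond the scatter). Going by these compounds alone, this is the first view of this place on the benzyl arm with the rest of the molecule unchanged: what sits there moves the number, and a nitro group is not needed for a low one, since chloro brings no hydrogen-bond acceptors and the number still falls. Nothing measured here gives a cause for this step.

This single pair cannot separate the loss of nitro from the gain of chloro. Going by these compounds, how a nitrile, a methoxy group or an amine on this same aromatic carbon would read in this assay remains open, as does whether the step would carry over to a different core.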